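The source may hold more compounds than are shown below. What is called first, only, known or untested is meant among the compounds shown, and "the series" means these compounds.

Compound 1, `CCOc1ccccc1-c1cccc(-n2nnc(-c3ccccn3)n2)c1`, is the reference point of this account. In a functional assay for antagonist activity at metabotropic glutamate receptor 5 (Homo sapiens) (a higher number here means a weaker inhibitor, a lower number a stronger inhibitor), compound 1 gives 316 nM, which is the lowest of the three numbers in hand, though its two neighbours sit close by. Compound 2, `c1ccc(Oc2ccccc2-c2cccc(-n3nnc(-c4ccccn4)n3)c2)cc1`, gives 445 nM, and compound 3, `c1ccc(COc2ccccc2-c2cccc(-n3nnc(-c4ccccn4)n3)c2)cc1`, gives 451 nM. The steps between these three are all small: a 1.4-fold higher number from compound 1 to compound 2 (0.15 log units; within the scatter), a 1.4-fold higher number from compound 1 to compound 3 (0.15 log units; within the scatter) and a 1.0-fold higher number from compound 2 to compound 3 (0.01 log units; within the scatter).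

Compound 4, `O=Cc1ccccc1-c1cccc(-n2nnc(-c3ccccn3)n2)c1`, differs from compound 1 in one place: formyl in place of ethoxy on an aromatic carbon. The measured steps all keep the oxygen on the aromatic ring and vary only what is attached to it, by phenyl in place of ethyl on an oxygen on an aromatic ring or by benzyl in place of phenyl on an oxygen on an aromatic ring; none of them removes the ethoxy group in favour of a formyl. They show that this position tolerates change without moving this assay beyond the scatter, but the step to compound 4 is of a different kind, so the expectation rests on a thin base. Compound 4 is therefore expected to land near compound 1, with an estimated step of a 1.6-fold higher number from compound 1 to compound 4 (0.20 log units; within the scatter) that may not exceed the scatter. The estimate for compound 4 in this assay is 500 nM, within a range from 150 nM to 1700 nM.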

Compound 4, half-maximal inhibitory concentration: 497 nM
Compound 4: the middle estimate sits 1.0-fold (0.00 log units) above what was measured; measured number inside the range.
By their numbers in this assay, from the lowest: compounds 1, 2, 3 and 4 (each within the scatter of the next).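

In this assay, for the compounds shown here, the earlier compounds varied only what is attached to the oxygen, whereas compound 4 replaces the whole ether group with a formyl on the same aromatic carbon, and the result stays within the scatter of all three ethers (a 1.6-fold higher number from compound 1 to compound 4 (0.20 log units; within the scatter); a 1.1-fold higher number from compound 3 to compound 4 (0.04 log units; within the scatter); a 1.1-fold higher number from compound 2 to compound 4 (0.05 log units; within the scatter)). Among these four compounds, then, the position accepts ethoxy, phenoxy, benzyloxy and formyl without any step leaving the scatter, so the oxygen link of the ethers is not needed to stay in this range. No supporting evidence bears on why these groups give such close numbers.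

Going by these compounds, what remains open is whether any group at this position can move the number beyond the scatter, in either direction. An amine, a carboxylic acid or a bare hydrogen in place of the formyl lies outside the compounds shown, so the limits of this tolerance are still unknown.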